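The source may report more compounds than this note shows. Statements on the series, on what has been measured and on what is new or still open speak of the compounds shown alone.

Measured so far:
Compound 1, `CN(C)CCCNc1nc(-c2ccc(NC(=O)Nc3ccccc3Cl)cc2)nc2ccsc12`, gives 390 nM.
Compound 2, `CCN(CC)CCCNc1nc(-c2ccc(NC(=O)Nc3ccc(Cl)cc3)cc2)nc2ccsc12`, gives 58 nM.

Both numbers come from a functional assay on HT-29 cells (Homo sapiens) for cytotoxicity, read by MTT assay, with a stated time of 72 h; a lower number here means a stronger inhibitor, a higher number a weaker inhibitor. Of the two, compound 2 gives the lower number, and the gap to compound 1 lies beyond the usual scatter, so compound 2 is the stronger inhibitor here. Compound 3, `CCN(CC)CCCNc1nc(-c2ccc(NC(=O)Nc3ccccc3Cl)cc2)nc2ccsc12`, is not yet measured. It differs from compound 2 in one place: 2-chlorophenyl in place of 4-chlorophenyl on an amide-type nitrogen. Compound 1 also carries 2-chlorophenyl at that position, but it differs from compound 2 in a second place as well, so the two measured values alone do not isolate the effect of moving the chlorine. For the measured compounds named here, still, the only measured compound with 2-chlorophenyl gives the weaker result, so the step from compound 2 to compound 3 is expected to go toward a higher number, of moderate size, estimated as a 2.6-fold higher number from compound 2 to compound 3 (0.41 log units; beyond the scatter). Compound 3 is therefore estimated at 150 nM, within a range from 55 nM to 400 nM.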

Compound 3, half-maximal inhibitory concentration: 340 nM
The estimate for compound 3 lay 2.3-fold (0.36 log units) below the measured number; low and high end bracket the measured number.
By their numbers in this assay, from the lowest: compound 2; then compounds 3 and 1 (each within the scatter of the next).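

In this assay, moving the chlorine can now be read on its own: 2-chlorophenyl in place of 4-chlorophenyl on the amide-type nitrogen is a clear loss of strength (a 5.9-fold higher number from compound 2 to compound 3 (0.77 log units; beyond the scatter)). This position therefore responds to where the chlorine sits, even though the group keeps the same atoms. With 2-chlorophenyl in place, diethylamino and dimethylamino on the chain cannot be told apart (a 1.1-fold lower number from compound 1 to compound 3 (0.06 log units; within the scatter)), and nothing available explains either result.

As far as these compounds go, whether those two amines would also read alike with 4-chlorophenyl on the amide-type nitrogen remains open. Also open, from the compounds shown here alone, is how a fluorophenyl or plain phenyl group would behave at that nitrogen, or a piperidine in place of diethylamino at the end of the chain.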